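The source may hold more compounds than are shown below. What is called first, only, known or untested is meant among the compounds shown, and "the series" means these compounds.

Compound 2, with the structure `ClCc1ccc(Cn2cnc3ncnc(Cl)c32)cc1`, is the starting point of this step. Within the data shown here, in a functional assay on SNB-75 cells (Homo sapiens) for cytotoxicity, read by sulforhodamine B assay, with a stated time of 48 h (on this read-out lower numbers stand for higher toxicity in this test and higher numbers for lower toxicity in this test), compound 2 gives "not determined" (no result reported), so no number stands for it, and the other compounds in the set are the only guide to where it might fall. Compound 1, with the structure `Nc1nc(Cl)c2ncn(Cc3ccc(CCl)cc3)c2n1`, carries an extra amino group on the shared core. In this assay compound 1 gives > 100000 nM, which is a limit of the assay and not a number; this is the point noted as the limit of > 100000 nM in this assay, at which 1 of the 3 values shown sits. Compound 3, with the structure `ClCc1cccc(Cn2cnc3ncnc(Cl)c32)c1`, is built from the same pieces as compound 2 joined at a different carbon of the benzyl ring. In this assay compound 3 gives 7940 nM.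

Compound 4, with the structure `ClCc1ccc(Cn2cnc3nc(Cl)nc(Cl)c32)cc1`, differs from compound 2 by one change: chloro in place of hydrogen on an aromatic carbon. Among the measured compounds shown here, no measured pair in the set makes the same change, so its size and direction cannot be read from the data. The step from compound 2 to compound 4 is expected to stay within the usual scatter in this assay, in either direction. Compound 4 is therefore estimated to give about 10000 nM in this assay, within a range of 2000 nM to 60000 nM.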

Compound 4, concentration lethal to 50% of the cells: 7410 nM
The estimate for compound 4 lay 1.3-fold (0.13 log units) above the measured number; measured number inside the range.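

Compound 2 has no reported result, so no step from compound 2 to compound 4 can be read, and no other compound shown differs from compound 4 in one place. Nothing shown bears on the value of compound 4. Going by these compounds, what chloro in place of hydrogen does in this assay remains open.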